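A Cyclobutyl Amide Replaces the Hydroxyl of Compound 1

A few compounds are considered here, and "the series" means these few. Any claim that something is new, unique, unknown or untested is made for them only; others in the source may bear on it.

Going by the values given here, compound 1 `N#Cc1cnc(NCc2cnccc2C(F)(F)F)cc1N[C@H]1C[C@H](O)C1` gives 900 nM in an assay on isolated protein for inhibition of protein kinase C theta type (Homo sapiens), read by TR-FRET, with a stated time of 2 h (a higher number here means a weaker inhibitor, a lower number a stronger inhibitor), the higher of the two numbers known here. Compound 2 `N#Cc1cnc(NCc2cncnc2OCC(F)F)cc1N[C@H]1CC[C@@H](O)CC1` gives 90 nM in this assay; it differs from compound 1 in more than one place, so only the two values themselves can be set side by side. Compound 3 `CC1(C)[C@@H](C(N)=O)C[C@H]1Nc1cc(NCc2cnccc2C(F)(F)F)ncc1C#N` keeps the core of compound 1 and carries the change (3-carbamoyl-2,2-dimethylcyclobutyl in place of 3-hydroxycyclobutyl on a nitrogen on an aromatic ring). Among the compounds with values here, no measured pair shows this exchange. Compound 3 is expected to give 300 nM in this assay, within 80 nM to 1200 nM. The expected step of a 3.0-fold lower number from compound 1 to compound 3 (0.48 log units; beyond the scatter) is a modest move toward a stronger inhibitor, of uncertain size.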

Compound 3, half-maximal inhibitory concentration: 1.4 nM
Compound 3: middle estimate off by 210-fold (2.33 log units), on the high side; the whole stated range lies above it.
By their numbers in this assay, from the lowest: compound 3; then compound 2; then compound 1.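

Going by these compounds alone, the exchange of 3-hydroxycyclobutyl for 3-carbamoyl-2,2-dimethylcyclobutyl, with the rest of compound 1 unchanged, gives a 640-fold lower number from compound 1 to compound 3 (2.81 log units; beyond the scatter) in this assay and is the first change here that can be read on its own. It shows that the group on this nitrogen can move the number by a large amount, and that the larger 3-carbamoyl-2,2-dimethylcyclobutyl group is accepted there. Nothing shown here accounts for the size of this step.

The compounds shown leave open how much of the step belongs to the carbamoyl group and how much to the two methyl groups, which enter together. From the compounds shown here alone, whether a carboxylic acid or an amine in place of the carbamoyl group would keep the gain also remains open.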